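A Chloro Step Carried Over to a Second Core

This account rests on a few compounds, and the source may have more. Where it says the series, first, only, none or still open, it means among the compounds named here.

Of the compounds shown here, three have been measured in a functional assay on BT-549 cells (Homo sapiens) for cytotoxicity, read by sulforhodamine B assay, with a stated time of 48 h; on this read-out lower numbers stand for stronger inhibition of growth and higher numbers for weaker inhibition of growth. Compound 1 `ClCc1ccccc1Cn1cnc2c(Cl)nc(Cl)nc21` gives 450 nM. Compound 2 `ClCc1ccccc1Cn1cnc2c(Cl)ncnc21` gives 1990 nM. Compound 3 `ClCc1cccc(Cn2cnc3ncnc(Cl)c32)c1` gives 13200 nM, the highest of the three numbers. Compound 2 and compound 3 are built from the same atoms joined differently; the difference between the two cores is not broken down here.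

Compound 1 and compound 2 differ in one place: chloro in place of hydrogen on an aromatic carbon. This change produced a 4.4-fold lower number from compound 2 to compound 1 (0.65 log units; beyond the scatter), a modest step that lies beyond the scatter.

Compound 4 `ClCc1cccc(Cn2cnc3nc(Cl)nc(Cl)c32)c1` has not yet been measured. It differs from compound 3 by chloro in place of hydrogen on an aromatic carbon. The place is described in the same words as for the change from compound 2 to compound 1, so it is the same change, made on the core of compound 3 instead.

On that basis the step of a 4.4-fold lower number from compound 3 to compound 4 (0.64 log units; beyond the scatter) is expected in this assay. Among the measured compounds shown here, the expectation rests on the single precedent, the step of a 4.4-fold lower number from compound 2 to compound 1 (0.65 log units; beyond the scatter). Compound 4 is therefore estimated to give about 3000 nM, with a plausible range from 1200 nM to 7500 nM.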

Compound 4, concentration for 50% growth inhibition: 480 nM
Beside the measured number, compound 4's estimate is 6.3-fold (0.80 log units) above it; measured number below the stated range.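

In this assay, chloro in place of hydrogen on an aromatic carbon between two ring nitrogen atoms gave a 28-fold lower number from compound 3 to compound 4 (1.44 log units; beyond the scatter) and so moved the number in the same direction as on the core of compound 2. The direction of the change therefore carried over to the second core, but its size did not. With only one pair on each core, this does not show what in the cores sets the size of the step, or how large the step would be on any further core, and the two steps differ by more than the scatter: the same change on two cores in this assay, a 4.4-fold lower number (0.65 log units; beyond the scatter) from compound 2 to compound 1 and a 28-fold lower number (1.44 log units; beyond the scatter) from compound 3 to compound 4, 6.2-fold (0.79 log units) apart, beyond the scatter of two such steps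

The compounds shown hold only chloro or hydrogen at this place, so it remains open whether a fluoro, a methoxy or an amine group there would follow either step. On these data alone, it also remains open whether an amine in place of the other chloro group would keep the larger step seen on the core of compound 3.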